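Swapping a methyl for fluoro on the aromatic ring

The source may report more compounds than this note shows. Statements on the series, on what has been measured and on what is new or still open speak of the compounds shown alone.

Of the compounds shown here, two sharing one core have been tested in a functional assay on the whole organism (strain Swiss albino) for inhibition, with Mus musculus as the target, in the formalin test, with a stated time of 30 min, at a dose of 100 mg/kg; on this read-out higher numbers stand for more inhibition at the one dose given (going by the name of the read-out) and lower numbers for less inhibition. Compound 1, with structure `CCN1CCc2c(c(C)nn2C(=O)Nc2cc(C)ccc2F)C1`, gives 15% in this assay. For the measured compounds named here, compound 2, with structure `CCN1CCc2c(c(C(C)(C)C)nn2C(=O)Nc2cc(C)ccc2C)C1`, gives 15.7% in this assay, a number that lies within the usual scatter of the one from compound 1, so the two cannot be told apart on these data.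

Compound 3, with structure `CCN1CCc2c(c(C(C)(C)C)nn2C(=O)Nc2cc(C)ccc2F)C1`, has not been measured yet. It differs from compound 2 in one place: fluoro in place of methyl on an aromatic carbon. Going by the values given here, no measured pair shows this change on its own, so there is no direct precedent for its size. Since compound 1 already carries fluoro at this position and its value sits where compound 2 sits, the step from compound 2 to compound 3 is expected to be a number 0.3 percentage points higher from compound 2 to compound 3 (within the scatter), that is, nothing beyond the scatter. Compound 3 is therefore estimated at 16% in this assay, within a range from 5% to 30%.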

Compound 3, a percentage reported as inhibition, in the whole organism at one dose (the size of the read-out at that dose, not a potency): 60.5%
Estimate against measurement, compound 3: 44.5 percentage points below, and the stated range ends below it.
By their numbers in this assay, from the lowest: compounds 1 and 2 (each within the scatter of the next); then compound 3.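

In this assay, fluoro in place of methyl on the aromatic ring gives a number 44.8 percentage points higher from compound 2 to compound 3 (beyond the scatter), and tert-butyl in place of methyl on the other aromatic carbon gives a number 45.5 percentage points higher from compound 1 to compound 3 (beyond the scatter). For the compounds shown here, compounds 1 and 2 could not be told apart, which made this position look unimportant, but compound 3 shows that one atom there can matter greatly, and that fluoro alone or tert-butyl alone does not carry the result: compound 3, the only compound with both, is the one that stands apart. Nothing shown here explains why these steps are so large.

The compounds shown say nothing about how chloro, methoxy or plain hydrogen would behave at the place of the fluoro. They also leave open whether isopropyl or cyclopropyl could stand in for tert-butyl.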